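This account rests on a few compounds, and the source may have more. Where it says the series, first, only, none or still open, it means among the compounds named here.

Measured compounds:
compound 1 `CN(c1cnccc1SCCCCCC(=O)O)c1ccc(C#N)c2ccccc12` — 3760 nM
compound 2 `N#Cc1ccc(Nc2cnccc2SCCCCCC(=O)O)c2ccccc12` — 4240 nM

In an assay on HEK293 cells for inhibition of solute carrier family 22 member 12 (Homo sapiens), read by scintillation counting, with stated times of 30 min and 15 min (on this read-out lower numbers stand for stronger inhibition and higher numbers for weaker inhibition), compound 1 gives 3760 nM and compound 2 gives 4240 nM; the step of a 1.1-fold higher number from compound 1 to compound 2 (0.05 log units; within the scatter) leaves the two indistinguishable, so compound 1 has no measured neighbour that is separated from it beyond the scatter. Compound 3 `CN(c1cnccc1SCCCCCCC(=O)O)c1ccc(C#N)c2ccccc12` differs from compound 1 by carboxymethyl in place of carboxy on a saturated chain carbon, five bonds along the chain from a sulfur. For the measured compounds named here, no measured step concerns this change: the only recorded step, from compound 1 to compound 2, alters the substituent on the aromatic nitrogen and says nothing about the length of the acid-bearing chain. Lengthening the chain by one carbon therefore has no precedent in the series, and the direction of any effect cannot be read from the data. The expected step of a 1.1-fold lower number from compound 1 to compound 3 (0.03 log units; within the scatter) is accordingly set close to zero, with a wide band to either side. Compound 3 is estimated at 3500 nM in this assay, with a range from 1200 nM to 10000 nM.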

Compound 3, half-maximal inhibitory concentration: 4640 nM
Estimate against measurement, compound 3: 1.3-fold (0.12 log units) below, and the stated range covers the measured number.
By their numbers in this assay, from the lowest: compounds 1, 2 and 3 (each within the scatter of the next).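

In this assay, for the compounds shown here, the step of a 1.2-fold higher number from compound 1 to compound 3 (0.09 log units; within the scatter) is the first reading on the acid-bearing chain rather than on the aromatic nitrogen: carboxymethyl in place of carboxy, on a saturated chain carbon, five bonds along the chain from a sulfur. Extending the chain of compound 1 by this one carbon thus produces no readable difference, so this position accepts the change without a measurable gain or loss. Nothing available bears on the reason for this result.

The compounds shown leave open whether a shorter chain or a still longer one would also stay within the scatter of compound 1, and what an amide or an ester in place of the carboxylic acid would give. Also open, as far as these compounds go, is whether the longer chain gives the same result when paired with the hydrogen on the nitrogen of compound 2.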